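Aryl changes on the shared core, toward compound 4

The source may hold more compounds than are shown below. What is called first, only, known or untested is meant among the compounds shown, and "the series" means these compounds.

Measured compounds:
compound 1 `CSc1ccc(C2=C(c3ccc(F)c(C)c3)C(=O)N3CCCC3C2)cc1`: 800 nM
compound 2 `CSc1ccc(C2=C(c3ccc(Br)cc3)C(=O)N3CCCC3C2)cc1`: 9000 nM
compound 3 `CSc1ccc(C2=C(c3ccc(C)cc3)C(=O)N3CCCC3C2)cc1`: 6000 nM

Compound 1 has the lowest number of the three in a functional assay on M14 cells (Homo sapiens) for cytotoxicity; on this read-out lower numbers stand for stronger inhibition of growth and higher numbers for weaker inhibition of growth. Going from 4-fluoro-3-methylphenyl to 4-methylphenyl gives a 7.5-fold higher number from compound 1 to compound 3 (0.88 log units; beyond the scatter), and going to 4-bromophenyl gives an 11-fold higher number from compound 1 to compound 2 (1.05 log units; beyond the scatter). Methyl in place of bromo then gives a 1.5-fold lower number from compound 2 to compound 3 (0.18 log units; within the scatter), which does not separate those two compounds.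

The next compound is compound 4 `CSc1ccc(C2=C(c3ccc(F)cc3)C(=O)N3CCCC3C2)cc1`, which has 4-fluorophenyl on the shared core. The change is hydrogen in place of methyl on an aromatic carbon. For the measured compounds named here, no measured step isolates this methyl. The closest evidence is that both measured departures from 4-fluoro-3-methylphenyl end higher, compound 3 at 6000 nM and compound 2 at 9000 nM. A rise in this assay is therefore expected, of similar or somewhat smaller size, since the fluoro group stays. The estimated step is a 4.4-fold higher number from compound 1 to compound 4 (0.64 log units; beyond the scatter). Compound 4 is expected at 3500 nM, with an estimated range of 1300 nM to 9500 nM.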

Compound 4, concentration for 50% growth inhibition: 600 nM
Estimate against measurement, compound 4: 5.8-fold (0.77 log units) above; the whole stated range lies above it.
By their numbers in this assay, from the lowest: compounds 4 and 1 (each within the scatter of the next); then compounds 3 and 2 (each within the scatter of the next).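

Hydrogen in place of methyl on an aromatic carbon gives a 1.3-fold lower number from compound 1 to compound 4 (0.12 log units; within the scatter) in this assay, so the methyl of 4-fluoro-3-methylphenyl is not needed for a low number in this series. The group that separates these compounds is the one that replaces fluoro: fluoro in place of methyl gives a 10-fold lower number from compound 3 to compound 4 (1.00 log units; beyond the scatter) and fluoro in place of bromo gives a 15-fold lower number from compound 2 to compound 4 (1.18 log units; beyond the scatter), which places the high numbers of compound 2 and compound 3 with the loss of the fluoro group rather than the loss of the methyl. Nothing measured here explains why fluoro separates from methyl and bromo.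

The compounds shown leave open how chloro, methoxy or an amine would read in place of the fluoro group. They also leave open whether the same order holds when the methylthio group on the other aryl ring is changed.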